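A few compounds are considered here, and "the series" means these few. Any claim that something is new, unique, unknown or untested is made for them only; others in the source may bear on it.

Measured in a functional assay on QGY-7703 cells (Homo sapiens) for cytotoxicity, read by MTT assay, with a stated time of 24 h; on this read-out lower numbers stand for stronger inhibition and higher numbers for weaker inhibition:
Compound 1 `CN1C/C(=C\c2ccncc2)C(=O)/C(=C/c2ccccc2F)C1`: 4900 nM
Compound 2 `O=C1/C(=C/c2ccncc2)CN(S(=O)(=O)c2ccc([N+](=O)[O-])cc2)C/C1=C\c1ccccc1F`: 8800 nM
Compound 3 `O=C1/C(=C/c2ccncc2)CN(S(=O)(=O)c2ccc(C(F)(F)F)cc2)C/C1=C\c1ccccc1F`: 9500 nM

Compound 3, at 9500 nM, lies within the usual scatter of both compound 1 and compound 2. Compound 4 `N#Cc1ccc(S(=O)(=O)N2C/C(=C\c3ccncc3)C(=O)/C(=C/c3ccccc3F)C2)cc1` departs from compound 3 by one change: cyano in place of trifluoromethyl on an aromatic carbon. Among the measured compounds shown here, only one measured step bears on this kind of swap: a 1.1-fold higher number from compound 2 to compound 3 (0.03 log units; within the scatter), where trifluoromethyl took the place of nitro on an aromatic carbon. That step stayed within the scatter, so a similar swap is expected to do the same, with no clear direction. The estimated change in this assay is therefore a 1.1-fold lower number from compound 3 to compound 4 (0.02 log units; within the scatter), and no step beyond the scatter is expected. For compound 4 the expected value is 9000 nM, with an estimated range from 4500 nM to 18000 nM.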

Compound 4, half-maximal inhibitory concentration: 8500 nM
Beside the measured number, compound 4's estimate is 1.1-fold (0.02 log units) above it; low and high end bracket the measured number.
By their numbers in this assay, from the lowest: compounds 1, 4, 2 and 3 (each within the scatter of the next).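

In this assay, cyano at this spot on the aromatic ring, para to a large group, gives a result that cannot be told apart from trifluoromethyl (a 1.1-fold lower number from compound 3 to compound 4 (0.05 log units; within the scatter)) or nitro (a 1.0-fold lower number from compound 2 to compound 4 (0.02 log units; within the scatter)). Even the swap of methyl on the ring's amine nitrogen for (4-cyanophenyl)sulfonyl stays within the scatter (a 1.7-fold higher number from compound 1 to compound 4 (0.24 log units; within the scatter)). No measurement here accounts for this flat picture. On these data alone, whether an amine or a carboxylic acid at the same spot on the aromatic ring would move the number beyond the scatter remains open.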